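Thiazolyl in Place of Cyanophenyl on a Shared Core

A few compounds are considered here, and "the series" means these few. Any claim that something is new, unique, unknown or untested is made for them only; others in the source may bear on it.

This account follows three compounds built on one shared core. Compound 1 `Cc1cc(Nc2cccc(Cl)c2)nc(N)n1` carries hydrogen on the aromatic carbon that the later compounds substitute. In an assay on cells for inhibition of S-adenosylmethionine decarboxylase proenzyme (Homo sapiens), read by mass spectrometry, at pH 7.2 (on this read-out lower numbers stand for stronger inhibition and higher numbers for weaker inhibition), compound 1 gives only a limit, > 180000 nM, and no number behind it. Compound 2 `Cc1cc(Nc2cc(Cl)cc(-c3ccc(C#N)cc3)c2)nc(N)n1` carries a 4-cyanophenyl group at that carbon. In this assay compound 2 likewise gives only a limit, > 7000 nM. Among the measured compounds shown here, the step that the two limits leave unreadable from compound 1 to compound 2 therefore cannot be read, as the limit of > 180000 nM in this assay, at which 1 of the 2 values shown sits, and the limit of > 7000 nM in this assay, at which 1 of the 2 values shown sits, show, and compound 2 stands at a limit, with the one further value shown being a limit as well.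

Compound 3 `Cc1cc(Nc2cc(Cl)cc(-c3cncs3)c2)nc(N)n1` differs from compound 2 in a single place: 1,3-thiazol-5-yl in place of 4-cyanophenyl on an aromatic carbon. For the measured compounds named here, no measured step bears readably on this change, since the only step shown sits between two limits and has no size. For compound 3 in this assay the expected step is a step that the limit leaves unreadable from compound 2 to compound 3, of no size that the data can support. The value of compound 3 is estimated at 10000 nM, within 2000 nM to 60000 nM, and a further limit rather than a number is quite possible.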

Compound 3, half-maximal inhibitory concentration: > 21000 nM
Compound 3: no number, only a limit; the forecaster's own chance of this, stated with the estimate: 60%; middle value at least 2.1-fold (0.32 log units) from the limit.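

In this assay compound 3 gives > 21000 nM, which is a limit and not a number. Among the compounds shown here, compound 1, compound 2 and compound 3 thus all stand at limits, and no step among them can be read. The compounds shown leave open how strongly any of the three inhibits, and whether 1,3-thiazol-5-yl and 4-cyanophenyl differ at all.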